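The source may report more compounds than this note shows. Statements on the series, on what has been measured and on what is new or still open speak of the compounds shown alone.

Measured so far:
compound 1 `COC(=O)[C@@]1(C)CCC=C2[C@@H]1CC[C@@H](C)[C@]2(C)Cc1c(C)[nH]c2ccccc12` — 17000 nM
compound 2 `COC(=O)[C@@]1(C)CCC=C2[C@@H]1CC[C@@H](C)[C@]2(C)Cc1c(C)[nH]c2ccc(OC)cc12` — 15000 nM

In a functional assay on T47D cells (Homo sapiens) for inhibition, read by sulforhodamine B assay, with a stated time of 48 h (on this read-out lower numbers stand for stronger inhibition of growth and higher numbers for weaker inhibition of growth), compound 1 gives 17000 nM, the highest of the two numbers. Its nearest neighbour is compound 2, which in this assay gives 15000 nM. Among the compounds with values here, the single measured step, a 1.1-fold lower number from compound 1 to compound 2 (0.05 log units; within the scatter), a methoxy in place of hydrogen on an aromatic carbon, stays within the scatter, so the series so far shows no change beyond the scatter from substitution on that ring.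

Compound 3 `COC(=O)[C@@]1(C)CCC=C2[C@@H]1CC[C@@H](C)[C@]2(C)Cc1c(C)[nH]c2c(Cl)cccc12` carries the change (chloro in place of hydrogen on an aromatic carbon). Within the data shown here, no measured step concerns a chloro group or this place on the ring; the only related evidence is the methoxy step from compound 1 to compound 2, which was within the scatter. On that basis no step beyond the scatter is expected, a 1.1-fold lower number from compound 1 to compound 3 (0.05 log units; within the scatter). Compound 3 is estimated at 15000 nM, with a range of 6000 nM to 40000 nM.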

Compound 3, concentration for 50% growth inhibition: 27000 nM
Estimate against measurement, compound 3: 1.8-fold (0.26 log units) below, and the stated range covers the measured number.
By their numbers in this assay, from the lowest: compounds 2, 1 and 3 (each within the scatter of the next).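

In this assay, chloro in place of hydrogen on an aromatic carbon, ortho to a fused ring and meta to a fused ring, gives a 1.6-fold higher number from compound 1 to compound 3 (0.20 log units; within the scatter), so a chloro group at this position leaves the number within the scatter of compound 1. Together with a 1.1-fold lower number from compound 1 to compound 2 (0.05 log units; within the scatter), this gives two different groups on the six-membered aromatic ring, neither producing a step beyond the scatter. No measurement of any property of the chloro group bears on this result.

From the compounds shown here alone, whether an amine or a carboxylic acid at this position would give a step beyond the scatter remains open. Also open, going by these compounds, is whether a change elsewhere on the shared core, such as a carboxylic acid in place of the ester, would shift the number further.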